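The source may report more compounds than this note shows. Statements on the series, on what has been measured and on what is new or still open speak of the compounds shown alone.

Measured compounds in an ADME assay on BJ cells (Homo sapiens) for cytotoxicity, with a stated time of 72 h; on this read-out higher numbers stand for an effect only at larger amounts of compound and lower numbers for an effect already at smaller amounts:

Compound 1 `CC(C)=CCC[C@@](C)(/C=C/c1ccccc1)/C=C/c1ccc(O)cc1`; in this assay compound 1 gives > 36600 nM, a limit of the assay.
Compound 2 `CC(C)=CCC[C@](C)(/C=C/c1ccc(O)cc1)/C=C/c1cccc(Cl)c1`; in this assay compound 2 gives > 36600 nM, a limit of the assay.
Compound 3 `C=C[C@@](C)(/C=C/c1ccc(Nc2ccc(Cl)cc2)cc1)CCC=C(C)C`; in this assay compound 3 gives > 36600 nM, a limit of the assay.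

All three values sit at the limit of > 36600 nM in this assay, at which 3 of the 3 values shown sit. The change from compound 1 to compound 2, (chloro in place of hydrogen on an aromatic carbon), gives a step that the two limits leave unreadable from compound 1 to compound 2, so its size is not readable from these two limits. The difference between the cores of compound 1 and compound 3 is not broken down here.

Compound 4 `C=C[C@@](C)(/C=C/c1ccc(Nc2ccc(Cl)c(Cl)c2)cc1)CCC=C(C)C` is the unmeasured member. It differs from compound 3 by chloro in place of hydrogen on an aromatic carbon. This is the same kind of change as from compound 1 to compound 2, but the place is not the same: in compound 4 the entering chloro sits ortho to a chloro group and meta to a large group, whereas in compound 2 it sits only meta to a large group.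

Given that compound 3 sits at the limit of > 36600 nM in this assay, at which 3 of the 3 values shown sit, the step that the limit leaves unreadable from compound 3 to compound 4 is expected to be small and compound 4 is expected to remain at the limit. Compound 4 is estimated at 50000 nM, within 20000 nM to 150000 nM.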

Compound 4, half-maximal effective concentration: > 36600 nM
Compound 4: only a limit was reported; the forecaster's own chance of this, stated with the estimate: 80%; the middle value does not contradict the limit.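

Compound 3 and compound 4 both carry only a limit of the assay in this assay, so no step can be read between them: the limit of > 36600 nM in this assay, at which 4 of the 4 values shown sit.

The compounds shown leave open whether the change from 4-chlorophenyl to 3,4-dichlorophenyl, or any other difference among them, alters cytotoxicity at amounts beyond that limit.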